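The source may hold more compounds than are shown below. What is called first, only, known or untested is meant among the compounds shown, and "the series" means these compounds.

In a functional assay on CCRF-CEM cells (Homo sapiens) for antiproliferative activity (on this read-out higher numbers stand for weaker inhibition and lower numbers for stronger inhibition), compound 2 `COc1cc(C(=O)c2sc(-c3ccc(I)cc3)cc2N)cc(OC)c1OC` gives 150 nM, the higher of the two numerical values, and compound 3 `COc1cc(C(=O)c2sc(-c3ccccc3)cc2N)cc(OC)c1OC` gives 4.5 nM. Compound 1 `COc1cc(C(=O)c2sc(-c3ccc(-c4ccccc4)cc3)cc2N)cc(OC)c1OC` reaches only a limit of the assay, > 10000 nM. Compound 4 `COc1cc(C(=O)c2sc(-c3ccccc3Cl)cc2N)cc(OC)c1OC` differs from compound 2 by 2-chlorophenyl in place of 4-iodophenyl on an aromatic carbon, with 2-chlorophenyl in place of 4-iodophenyl. The nearest measured change is hydrogen in place of iodo, a 33-fold lower number from compound 2 to compound 3 (1.52 log units; beyond the scatter), and hydrogen in place of phenyl, an at least 2200-fold lower number from compound 1 to compound 3 (3.34 log units; beyond the scatter), runs the same way. Within the data shown here, no measured compound carries 2-chlorophenyl. Among the measured compounds shown here, a lower number is expected in this assay, though a smaller change than the one measured for compound 3 at 4.5 nM. The expected step is a 3.0-fold lower number from compound 2 to compound 4 (0.48 log units; beyond the scatter). For compound 4 the estimate is 50 nM, within an expected range of 8 nM to 400 nM.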

Compound 4, half-maximal inhibitory concentration: 16 nM
Compound 4: the middle estimate sits 3.1-fold (0.49 log units) above what was measured; the range from low to high includes it.
By their numbers in this assay, from the lowest: compound 3; then compound 4; then compound 2. At a limit, above all of these: compound 1.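

In this assay, the group next to the ring sulfur accepts a halogen on its phenyl ring far better as 2-chlorophenyl than as 4-iodophenyl, with a 9.4-fold lower number from compound 2 to compound 4 (0.97 log units; beyond the scatter) for this swap. Chloro still costs something against the bare phenyl, with a 3.6-fold higher number from compound 3 to compound 4 (0.55 log units; beyond the scatter) for that addition. Nothing measured here bears on the reason for either step.

From the compounds shown here alone, the swap changes the halogen and its place on the ring together, so the share of each stays open. Going by these compounds, the effect of an amine or a carboxylic acid on that phenyl ring also stays open.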